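The source may hold more compounds than are shown below. What is called first, only, known or untested is meant among the compounds shown, and "the series" means these compounds.

Three compounds have been measured in an ADME assay on C8166 cells (Homo sapiens) for cytotoxicity, read by colorimetric assay and MTT assay; on this read-out lower numbers stand for higher toxicity in this test and higher numbers for lower toxicity in this test:

compound 1 `Cc1cc(S(N)(=O)=O)ccc1NC(=O)COc1ccc2ccccc2c1C(=O)c1cccc(Cl)c1` gives 37400 nM
compound 2 `Cc1cc(S(N)(=O)=O)ccc1NC(=O)COc1ccc2ccccc2c1C(=O)c1cc(Cl)cc(Br)c1` gives 36600 nM
compound 3 `Cc1cc(S(N)(=O)=O)ccc1NC(=O)COc1ccc2ccccc2c1C(=O)c1cc(Cl)cc(C#N)c1` gives 49400 nM

Compound 1 stands second highest of the three numbers in this assay; its nearest neighbour is compound 2 and its furthest is compound 3, and neither gap goes beyond the scatter. Compound 4 `Cc1cc(S(N)(=O)=O)ccc1NC(=O)COc1ccc2cc(Br)ccc2c1C(=O)c1cccc(Cl)c1` differs from compound 1 by bromo in place of hydrogen on an aromatic carbon. For the measured compounds named here, no measured step places a group on that part of the shared core. The measured steps instead place groups elsewhere in the core: a 1.0-fold lower number from compound 1 to compound 2 (0.01 log units; within the scatter), a 1.3-fold higher number from compound 1 to compound 3 (0.12 log units; within the scatter) and a 1.3-fold higher number from compound 2 to compound 3 (0.13 log units; within the scatter), each within the scatter. Those steps show that adding a bromo or a cyano group there left the numbers in this assay essentially where they were, so for compound 4 a step of no more than the scatter is expected, in no particular direction, which gives a 1.0-fold lower number from compound 1 to compound 4 (0.00 log units; within the scatter). Compound 4 is therefore estimated at 37000 nM, with a range from 18000 nM to 75000 nM.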

Compound 4, half-maximal cytotoxic concentration: 6800 nM
Compound 4: middle estimate off by 5.4-fold (0.74 log units), on the high side; measured number below the stated range.
By their numbers in this assay, from the lowest: compound 4; then compounds 2, 1 and 3 (each within the scatter of the next).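

In this assay, bromo in place of hydrogen on this aromatic carbon, part of a fused system of two rings, gives a 5.5-fold lower number from compound 1 to compound 4 (0.74 log units; beyond the scatter) and so moves the number beyond the scatter. The same replacement elsewhere in the core gives a 1.0-fold lower number from compound 1 to compound 2 (0.01 log units; within the scatter) and leaves the number within the scatter, so among these compounds the place of the bromo matters, not merely its presence. Nothing measured here explains this drop.

On these data alone, it remains open whether only bromo lowers the number at this position, or whether another group there, such as a methoxy group or an amine, would do the same. As far as these compounds go, it is also open whether bromo at this position would lower the number as much if the cyano group of compound 3 were present.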